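The source may report more compounds than this note shows. Statements on the series, on what has been measured and on what is new or still open speak of the compounds shown alone.

Three compounds of the series have been run in a functional assay on B16 cells (Mus musculus) for cytotoxicity, read by MTT assay, with a stated time of 72 h (a higher number here means a weaker inhibitor, a lower number a stronger inhibitor), all sharing a core that carries a 3,4,5-trimethoxyphenyl group. Compound 1 `COc1cc(C2=NN(C(C)=O)C(c3ccc(Cl)cc3)C2)cc(OC)c1OC` gives 35000 nM in this assay. Compound 2 `COc1ccc(C2CC(c3cc(OC)c(OC)c(OC)c3)=NN2)cc1OC` gives 44000 nM. For compound 3 `COc1ccc(C2CC(c3cc(OC)c(OC)c(OC)c3)=NN2C(C)=O)cc1O` this assay reports only a limit, > 100000 nM. For the measured compounds named here, the single measured step, an at least 2.8-fold higher number from compound 1 to compound 3 (0.45 log units; beyond the scatter), is consequently a bound rather than a number, resting on (the limit of > 100000 nM in this assay, at which 1 of the 3 values shown sits). Compound 3 thus stands at the limit of the assay, without a fixed value of its own.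

Compound 4 `COc1ccc(C2CC(c3cc(OC)c(OC)c(OC)c3)=NN2)cc1O` differs from compound 3 by hydrogen in place of acetyl on an amine nitrogen in a ring. Going by the values given here, no measured step concerns the acetyl: the step from compound 1 to compound 3 changes the aryl group on the saturated ring carbon, not the ring nitrogen. Compound 1 and compound 2 differ in two places at once, acetyl and aryl, and their values lie close together, so the acetyl cannot be read out separately. Compound 2 is the nearest measured neighbour of compound 4 and sits at a finite value. Compound 4 is therefore expected to fall between the limit of compound 3 and the value of compound 2. The step of an at least 1.2-fold lower number from compound 3 to compound 4 (0.09 log units; that floor lies within the scatter) is the expected outcome. The estimate for compound 4 is 80000 nM, with a range from 30000 nM to 200000 nM.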

Compound 4, half-maximal inhibitory concentration: 2100 nM
Compound 4: the middle estimate sits 38-fold (1.58 log units) above what was measured; measured number below the stated range.
By their numbers in this assay, from the lowest: compound 4; then compounds 1 and 2 (each within the scatter of the next). At a limit, above all of these: compound 3.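

In this assay, for the compounds shown here, hydrogen in place of acetyl on the amine nitrogen in the ring gives an at least 47-fold lower number from compound 3 to compound 4 (1.67 log units; beyond the scatter), the first reading of this position on its own, and the acetyl is clearly not tolerated in this pair. Compound 3 has only a limit, > 100000 nM, so the size of that step is a bound: the limit of > 100000 nM in this assay, at which 1 of the 4 values shown sits. With hydrogen on the ring nitrogen, hydrogen in place of methyl on an oxygen on the aromatic ring gives a 21-fold lower number from compound 2 to compound 4 (1.32 log units; beyond the scatter), showing that this single change matters and that the free ring nitrogen alone does not account for the level of compound 4.

Going by these compounds, whether the same oxygen change has any such effect with acetyl on the ring nitrogen remains open. Also open, on these data alone, is how a formyl group or a longer acyl chain on that nitrogen, or an amine in place of the hydroxyl on the aromatic ring, would read.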